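A Cyclohexyl Group Replaces 1-Hydroxyethyl

The source may hold more compounds than are shown below. What is called first, only, known or untested is meant among the compounds shown, and "the series" means these compounds.

Three compounds with a shared core differ in one group on an aromatic carbon: cyclopropyl in compound 1 `Brc1cnn2c(NCc3cccnc3)cc(C3CC3)nc12`, 1-hydroxyethyl in compound 2 `CC(O)c1cc(NCc2cccnc2)n2ncc(Br)c2n1` and methylamino in compound 3 `CNc1cc(NCc2cccnc2)n2ncc(Br)c2n1`. In a functional assay on cells (Homo sapiens), read by thymidine incorporation (a lower number here means a stronger inhibitor, a higher number a weaker inhibitor), compound 1 gives 1500 nM, compound 2 gives 1400 nM and compound 3 gives 1200 nM. Compound 2 thus stands within the scatter of both of the others.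

Compound 4 `Brc1cnn2c(NCc3cccnc3)cc(C3CCCCC3)nc12` carries cyclohexyl in place of 1-hydroxyethyl on that aromatic carbon: cyclohexyl in place of 1-hydroxyethyl on an aromatic carbon.

Among the compounds with values here, the only evidence comes from earlier swaps at this same carbon. These are a 1.1-fold lower number from compound 1 to compound 2 (0.03 log units; within the scatter), a 1.2-fold lower number from compound 2 to compound 3 (0.07 log units; within the scatter) and a 1.3-fold lower number from compound 1 to compound 3 (0.10 log units; within the scatter), and all three stay within the scatter. Within the data shown here, no measured compound has a six-membered ring there, so the evidence is thin and the range must stay wide. In this assay the expected change is a 1.1-fold lower number from compound 2 to compound 4 (0.03 log units; within the scatter), which amounts to no clear step in either direction. The estimate for compound 4 is 1300 nM, with an expected range from 500 nM to 3500 nM.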

Compound 4, half-maximal inhibitory concentration: 200 nM
Compound 4: the middle estimate sits 6.5-fold (0.81 log units) above what was measured, outside the stated range (below it).
By their numbers in this assay, from the lowest: compound 4; then compounds 3, 2 and 1 (each within the scatter of the next).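

Cyclopropyl, 1-hydroxyethyl and methylamino gave no clear separation at this carbon, so it could have seemed to tolerate changes without much effect. Cyclohexyl shows that the group here can matter in this assay: the number falls in each comparison, with a 7.0-fold lower number from compound 2 to compound 4 (0.85 log units; beyond the scatter) and a 6.0-fold lower number from compound 3 to compound 4 (0.78 log units; beyond the scatter) and a 7.5-fold lower number from compound 1 to compound 4 (0.88 log units; beyond the scatter) all beyond the scatter. No measurement shown explains why this six-membered carbon ring stands apart from the other three groups.

The compounds shown leave open whether the effect needs a ring of this size, which cyclopentyl or cycloheptyl could test, or simply this much carbon, which an open hexyl chain could test. Also open, as far as these compounds go, is whether an aromatic phenyl ring or a nitrogen-containing piperidine ring would give a similar number.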